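Shifting a chlorine around the amide-bound ring

The source may report more compounds than this note shows. Statements on the series, on what has been measured and on what is new or still open speak of the compounds shown alone.

Measured so far:
- compound 1 `CCc1cccc(NC(=O)CSc2nc(Nc3ccccc3)c3ccccc3n2)c1`: 12000 nM
- compound 2 `O=C(CSc1nc(Nc2ccccc2)c2ccccc2n1)Nc1ccc(C(F)(F)F)cc1`: 11700 nM
- compound 3 `O=C(CSc1nc(Nc2ccccc2)c2ccccc2n1)Nc1ccc(Cl)cc1Cl`: 8410 nM

In a functional assay on NCI-H1975 cells (Homo sapiens) for inhibition, read by MTT assay, with a stated time of 72 h (on this read-out lower numbers stand for stronger inhibition and higher numbers for weaker inhibition), compound 3 gives 8410 nM. Its number sits together with those of compound 1 and compound 2: the steps of a 1.4-fold lower number from compound 1 to compound 3 (0.15 log units; within the scatter) and a 1.4-fold lower number from compound 2 to compound 3 (0.14 log units; within the scatter), like a 1.0-fold lower number from compound 1 to compound 2 (0.01 log units; within the scatter), stay within the scatter, so the three aryl groups on the amide nitrogen cannot be told apart on these numbers. Compound 4 `O=C(CSc1nc(Nc2ccccc2)c2ccccc2n1)Nc1ccc(Cl)c(Cl)c1` carries 3,4-dichlorophenyl in place of 2,4-dichlorophenyl on an amide-type nitrogen. For the measured compounds named here, no measured step swaps two dichlorophenyl patterns, so the closest guidance is that every change at this position so far left this assay unmoved. A step of a 1.0-fold higher number from compound 3 to compound 4 (0.00 log units; within the scatter) is therefore expected, no more than the scatter. Compound 4 is estimated at 8500 nM, within 3500 nM to 22000 nM.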

Compound 4, half-maximal inhibitory concentration: 10400 nM
Compound 4: the middle estimate sits 1.2-fold (0.09 log units) below what was measured; measured number inside the range.
By their numbers in this assay, from the lowest: compounds 3, 4, 2 and 1 (each within the scatter of the next).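

In this assay, moving one chlorine, with 3,4-dichlorophenyl in place of 2,4-dichlorophenyl, gives a 1.2-fold higher number from compound 3 to compound 4 (0.09 log units; within the scatter) and so shows that this swap between two patterns of the same atoms stays within the scatter. The other comparisons agree: a 1.1-fold lower number from compound 2 to compound 4 (0.05 log units; within the scatter) and a 1.2-fold lower number from compound 1 to compound 4 (0.06 log units; within the scatter) also stay inside it, so all four aryl groups on the amide nitrogen read alike here. Nothing available explains this sameness. Still open, on these data alone, is whether a group of another kind at this position, such as a phenyl ring carrying a carboxylic acid or an amine, would separate from these four compounds.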